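The source may report more compounds than this note shows. Statements on the series, on what has been measured and on what is new or still open speak of the compounds shown alone.

Measured compounds:
- compound 1 `OCC(O)Cn1nc2c(Br)c(Br)c(Br)c(Br)c2n1`: 53%
- compound 2 `OC(CCn1nc2c(Br)c(Br)c(Br)c(Br)c2n1)c1ccc(Br)cc1`: 0%
- compound 3 `OC(CCn1nc2c(Br)c(Br)c(Br)c(Br)c2n1)c1cccc(Cl)c1`: 0%

In a functional assay on MCF7 cells (Homo sapiens) for antiproliferative activity, read by MTT assay, with a stated time of 24 h, tested at 100 uM (on this read-out higher numbers stand for a weaker effect at the one concentration tested and lower numbers for a stronger effect), compound 3 gives 0%, level with compound 2 within the scatter, and together these two are the lowest of the three numbers. Compound 1 stands a long way higher; the step from compound 3 to compound 1 is well beyond the scatter.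

Compound 4 `CC(O)CCn1nc2c(Br)c(Br)c(Br)c(Br)c2n1` differs from compound 3 in one place: methyl in place of 3-chlorophenyl on a saturated chain carbon bound to an oxygen on a saturated carbon and a saturated chain carbon. Going by the values given here, the only measured step, no change at the digits printed from compound 2 to compound 3 (within the scatter), swaps one six-membered aromatic ring for another and so says little about taking the ring away altogether. Compound 1, which also lacks an aromatic ring on its chain, gives 53%, though its chain differs in more than one place from that of compound 4. The expectation is therefore a sizeable move toward weaker effect, roughly a number 45 percentage points higher from compound 3 to compound 4 (beyond the scatter), with wide uncertainty. Compound 4 is estimated at 45% in this assay, in a range from 15% to 80%.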

Compound 4, a percentage reported as activity, at one concentration (the size of the read-out at that concentration, not a potency): 57%
For compound 4 the middle estimate is 12 percentage points below the measured one, within the range that was stated.
By their numbers in this assay, from the lowest: compounds 2 and 3 (each within the scatter of the next); then compounds 1 and 4 (each within the scatter of the next).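

In this assay the group on this chain carbon matters a great deal: methyl in place of 3-chlorophenyl gives a number 57 percentage points higher from compound 3 to compound 4 (beyond the scatter) and methyl in place of 4-bromophenyl gives a number 57 percentage points higher from compound 2 to compound 4 (beyond the scatter) on the same carbon. The earlier swap of one aromatic ring for another showed no such move, whereas here both ring-bearing compounds keep the stronger effect at the one concentration tested and methyl does not. Exchanging the chain, with 2-hydroxypropyl in place of 1,2-dihydroxyethyl, gives only a number 4 percentage points higher from compound 1 to compound 4 (within the scatter) and so cannot separate these two chains.

On these data alone, whether a cyclohexyl group or an amine on this carbon would behave like the aromatic rings or like methyl remains open. No measurement shown explains why removing the aromatic ring has this effect.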